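The source may report more compounds than this note shows. Statements on the series, on what has been measured and on what is new or still open speak of the compounds shown alone.

In a functional assay on C-33-A cells (Homo sapiens) for cytotoxicity, read by sulforhodamine B assay, with a stated time of 48 h (on this read-out lower numbers stand for stronger inhibition and higher numbers for weaker inhibition), compound 2 `CCOC(=O)c1cc2cc(/C=C/C(=O)c3ccc(C)cc3)cc(C(C)CC)c2oc1=O` gives 3590 nM, and compound 3 `CCOC(=O)c1cc2cc(/C=C/C(=O)c3ccccc3)cc(C(C)CC)c2oc1=O` gives 8120 nM. Within the data shown here, the one step between them, a 2.3-fold higher number from compound 2 to compound 3 (0.35 log units; beyond the scatter), is a modest move to a weaker result. Compound 1 `CCC(C)c1cc(/C=C/C(=O)c2ccc(Cl)cc2)cc2cc(C(C)=O)c(=O)oc12` was reported in this assay as "not active" (no number reported), with no number given. Among the measured compounds shown here, compound 3 therefore holds the highest of the two numbers available, with compound 2 as its only neighbour.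

Compound 4 `CCOC(=O)c1cc2cc(/C=C/C(=O)c3ccc(Cl)cc3)cc(C(C)CC)c2oc1=O` differs from compound 3 by chloro in place of hydrogen on an aromatic carbon. For the measured compounds named here, no measured step shows this exact change on this core; the only related observation is that adding a methyl at the same kind of position, read backwards from compound 3 to compound 2, lowered the number. Compound 1, which also carries a chloro there but on a different core, gave no number. A step of about the size of a 1.8-fold lower number from compound 3 to compound 4 (0.26 log units; within the scatter) toward a lower number is therefore expected for compound 4, with an estimate of 4500 nM and a range of 1800 nM to 14000 nM.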

Compound 4, half-maximal inhibitory concentration: 4540 nM
Compound 4: the middle estimate sits 1.0-fold (0.00 log units) below what was measured, within the range that was stated.
By their numbers in this assay, from the lowest: compounds 2, 4 and 3 (each within the scatter of the next, the first and the last beyond it).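

In this assay chloro in place of hydrogen on this aromatic carbon gives a 1.8-fold lower number from compound 3 to compound 4 (0.25 log units; within the scatter) and chloro in place of methyl gives a 1.3-fold higher number from compound 2 to compound 4 (0.10 log units; within the scatter) and so compound 4 cannot be told apart from either neighbour, even though those two neighbours are separated from each other. Compound 1, with the same 4-chlorophenyl but acetyl in place of the ethyl ester, reads "not active" (no number reported) while compound 4 gives a number, so chloro alone does not go with that result.

On these data alone, whether a methoxy group, an amine or bromine on this carbon would stand apart from these compounds remains open. Nothing available explains why these groups read as they do.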